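The source may hold more compounds than are shown below. What is called first, only, known or untested is meant among the compounds shown, and "the series" means these compounds.

Measured so far in a functional assay on the whole organism (Testis, strain Long-Evans) with Rattus norvegicus as the target, with a stated time of 5 days; on this read-out lower numbers stand for an effect already at smaller amounts and higher numbers for an effect only at larger amounts of compound:

- compound 1 `O=C(O)c1nn(Cc2cccc(Cl)c2)c2ccccc12` gives 400 mg/kg
- compound 2 `O=C(O)c1nn(Cc2ccccc2Cl)c2ccccc12` gives 200 mg/kg
- compound 3 `O=C(O)c1nn(Cc2cc(Cl)c(Cl)cc2Cl)c2ccccc12` gives 248 mg/kg

Three compounds share the same core and differ only in the substitution of the benzyl ring. Compound 2 has the lowest of the three numbers in this assay, but the gaps to compound 3 and to compound 1 both lie within the scatter of repeated measurements, so no order among the three can be read from these numbers; they are, on what is shown, indistinguishable.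

Compound 4 `Cc1ccccc1Cn1nc(C(=O)O)c2ccccc21` has not yet been measured. It differs from compound 2 in one place: methyl in place of chloro on an aromatic carbon. One heavy atom is exchanged for another, no ring, no donor or acceptor and no charge is added or removed, and the position on the six-membered aromatic ring of carbon only is kept.

Among the compounds with values here, no measured pair shows what such a step does in this assay, and the three measured compounds, with varied chlorine patterns on that ring, give numbers that do not separate from one another. The expected step is therefore none beyond the scatter, in either direction. Compound 4 is estimated at 250 mg/kg, with a range from 120 mg/kg to 500 mg/kg, which means an expected step of a 1.3-fold higher number from compound 2 to compound 4 (0.10 log units; within the scatter) that stays within the usual scatter.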

Compound 4, minimum effective dose: 186 mg/kg
The estimate for compound 4 lay 1.3-fold (0.13 log units) above the measured number; the range from low to high includes it.
By their numbers in this assay, from the lowest: compounds 4, 2, 3 and 1 (each within the scatter of the next, the first and the last beyond it).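

In this assay, within the data shown here, methyl in place of chloro on an aromatic carbon, ortho to a large group, gives a 1.1-fold lower number from compound 2 to compound 4 (0.03 log units; within the scatter) and so provides the first step that changes one place only. At this place the two groups cannot be told apart on this read-out, and a chlorine on the benzyl ring is not required for a number in this range, since compound 4 carries none and stays within the scatter of compound 2. Nothing measured on these compounds offers an explanation for this outcome.

Still open, going by these compounds, is whether a group that departs further from chloro and methyl, such as an amine, a methoxy group or a longer chain like propyl, would give a number that separates from compound 2 at this place. The compounds shown also leave open what a benzyl ring with no substituent at all would give, and whether the carboxylic acid on the shared core could give way to an amide or an ester on this read-out.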